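A few compounds are considered here, and "the series" means these few. Any claim that something is new, unique, unknown or untested is made for them only; others in the source may bear on it.

In a functional assay on MDA-MB-231 cells (Homo sapiens) for antiproliferative activity, with a stated time of 5 days (a lower number here means a stronger inhibitor, a higher number a weaker inhibitor), compound 2 (`O=C1C=CC2(C=C1)OCC(=O)N2c1nc(-c2ccc3ccccc3c2)nn1-c1ccc(Cl)cc1`) gives 70 nM and compound 1 (`O=C1C=CC2(C=C1)OCC(=O)N2c1nc(-c2ccc3c(c2)OCCO3)nn1-c1ccccc1`) gives 100 nM, two values within the scatter of each other. Within the data shown here, these two compounds differ in more than one place, so no single-change step is yet available to guide the next reading. Compound 3 (`O=C1C=CC2(C=C1)OCC(=O)N2c1nc(-c2ccc3ccccc3c2)nn1-c1ccccc1`) is compound 2 with hydrogen in place of chloro on an aromatic carbon, that is, 4-chlorophenyl to phenyl: hydrogen in place of chloro on an aromatic carbon. Compound 1 also carries phenyl rather than 4-chlorophenyl and still gives 100 nM, which offers only loose support, as its other substituent differs too. In this assay no change beyond the scatter is expected, with at most a slight drift towards a higher number. The expected step is a 1.3-fold higher number from compound 2 to compound 3 (0.11 log units; within the scatter). For compound 3 the estimated value is 90 nM, with an expected range of 35 nM to 230 nM.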

Compound 3, half-maximal inhibitory concentration: 70 nM
The estimate for compound 3 lay 1.3-fold (0.11 log units) above the measured number; the range from low to high includes it.
By their numbers in this assay, from the lowest: compounds 2, 3 and 1 (each within the scatter of the next).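

In this assay, among these compounds, hydrogen in place of chloro on an aromatic carbon gives no change at the digits printed from compound 2 to compound 3 (within the scatter), the first single-change reading at this place, and it shows that the series keeps its number without the chloro. Naphthalen-2-yl in place of 2,3-dihydro-1,4-benzodioxin-6-yl gives a 1.4-fold lower number from compound 1 to compound 3 (0.15 log units; within the scatter), so this second single change also separates nothing in this assay. No supporting measurement bears on either reading.

Still open, from the compounds shown here alone, is whether a group other than chloro on the phenyl ring, such as methoxy, an amine or a carboxylic acid, would move the number beyond the scatter. Also open, going by these compounds, is whether a replacement for the naphthalen-2-yl group, such as a pyridine ring, would separate from these three compounds in this assay.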